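A few compounds are considered here, and "the series" means these few. Any claim that something is new, unique, unknown or untested is made for them only; others in the source may bear on it.

Measured so far in a functional assay on ASPC1 cells (Homo sapiens) for inhibition, read by MTT assay, with a stated time of 72 h; on this read-out lower numbers stand for stronger inhibition of growth and higher numbers for weaker inhibition of growth:
compound 1, `O=S(=O)(NCCNCc1cccc2ccccc12)c1cc(C(F)(F)F)cc(C(F)(F)F)c1`: 22000 nM
compound 2, `O=S(=O)(NCCCNCc1ccccc1Cl)c1cc(C(F)(F)F)cc(C(F)(F)F)c1`: 13000 nM

Compound 2 has the lower of these two numbers, but its gap to compound 1 lies within the scatter, so the two cannot be ranked against each other. Compound 3, `CC(C)(C)c1ccc(CNCCCNS(=O)(=O)c2cc(C(F)(F)F)cc(C(F)(F)F)c2)cc1`, differs from compound 2 in one place: 4-(tert-butyl)phenyl in place of 2-chlorophenyl on a saturated chain carbon bound to an amine nitrogen. Within the data shown here, no measured pair shows this change, so the numbers give no direction for it. The step of a 1.1-fold lower number from compound 2 to compound 3 (0.03 log units; within the scatter) is therefore expected to stay within the scatter. In this assay compound 3 is expected to give about 12000 nM, estimated to lie between 4000 nM and 35000 nM.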

Compound 3, concentration for 50% growth inhibition: 2700 nM
Compound 3: middle estimate off by 4.4-fold (0.65 log units), on the high side, and the stated range ends above it.
By their numbers in this assay, from the lowest: compound 3; then compounds 2 and 1 (each within the scatter of the next).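

In this assay, 4-(tert-butyl)benzyl in place of 2-chlorobenzyl gives a 4.8-fold lower number from compound 2 to compound 3 (0.68 log units; beyond the scatter), so growth inhibition does respond to the group at this place, on a saturated chain carbon bound to an amine nitrogen. Compound 1 and compound 2 differ in more than one place and could not show this. Nothing available explains the size of this step.

Going by these compounds, the swap removes the chlorine and adds the tert-butyl together, so the contribution of each remains open. A plain benzyl or a pyridylmethyl group at this place would be informative comparisons.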